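Replacing the ring on sulfur in compound 2

The source may hold more compounds than are shown below. What is called first, only, known or untested is meant among the compounds shown, and "the series" means these compounds.

Compound 1 `COc1ccc(SCc2ccc(C(=O)Nc3ccccc3N)cc2)cc1`: 70.7%
Compound 2 `Nc1ccccc1NC(=O)c1ccc(CSc2ccc(Cl)cc2)cc1`: 50.4%

Both values come from a functional assay on A549 cells (Homo sapiens) for inhibition, read by CCK-8 assay, with a stated time of 72 h, tested at 8 uM (on this read-out higher numbers stand for more inhibition of growth at the one concentration tested and lower numbers for less inhibition of growth), and compound 2 holds the lower of the two. The next compound, compound 3 `Cc1cc(C)cc(SCc2ccc(C(=O)Nc3ccccc3N)cc2)c1`, has 3,5-dimethylphenyl in place of 4-chlorophenyl on a sulfur. For the measured compounds named here, only one measured step bears on this change. That step, a number 20.3 percentage points lower from compound 1 to compound 2 (beyond the scatter), put chloro in place of methoxy on an aromatic carbon, and it lies beyond the usual scatter. It shows that a change on this ring can move the number, and compound 3 also has no chloro. Going by the values given here, no measured compound carries methyl groups, however, so the guide is only partial. The expected change is upward but smaller than that step, at a number 9.6 percentage points higher from compound 2 to compound 3 (within the scatter). For compound 3 the estimate is 60%, with an expected range from 42% to 78%.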

Compound 3, percent growth inhibition at one concentration: 78.5%
Compound 3: the middle estimate sits 18.5 percentage points below what was measured; the whole stated range lies below it.
By their numbers in this assay, from the lowest: compound 2; then compounds 1 and 3 (each within the scatter of the next).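

Placing 3,5-dimethylphenyl on a sulfur in place of 4-chlorophenyl gives a number 28.1 percentage points higher from compound 2 to compound 3 (beyond the scatter) in this assay, so the earlier drop with chloro is now seen from a second direction. Set against the methoxy ring, the same group gives a number 7.8 percentage points higher from compound 1 to compound 3 (within the scatter), which means that compound 1 and compound 3 cannot be told apart here, although one ring carries an oxygen-linked group and the other only carbon groups. Nothing available explains why compound 2 stands lowest of the three.

As far as these compounds go, the step to compound 3 removes chloro and adds two methyl groups at once, so the share of each remains open. Also open, from the compounds shown here alone, is how this ring would fare with a single methyl group, an amine or a carboxylic acid in place of these groups.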